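The source may hold more compounds than are shown below. What is called first, only, known or untested is meant among the compounds shown, and "the series" means these compounds.

Compound 3 `C[n+]1ccn(COCC[N+](=O)[O-])c1/C=N/O` gives no result reported in a physicochemical assay for lipophilicity (on this read-out higher numbers stand for higher lipophilicity and lower numbers for lower lipophilicity), so it cannot be placed on the scale. The change to compound 4 `C[n+]1ccn(COCC(C)(C)[N+](=O)[O-])c1/C=N/O` is 1-methyl-1-nitroethyl in place of nitromethyl on a saturated chain carbon bound to an oxygen on a saturated carbon. Among the measured compounds shown here, one measured step bears on this. Compound 1 `COCCOCn1cc[n+](C)c1/C=N/O` gives -2.81 in this assay, and compound 2 `COC(C)CCOCn1cc[n+](C)c1/C=N/O` gives -2.22. That step, a number 0.59 log units higher from compound 1 to compound 2 (beyond the scatter), came from a single methyl entering a saturated chain. Here a larger group enters, so a rise in this assay of at least that order is expected, though the missing value for compound 3 leaves the starting point open and widens the range. Compound 4 is estimated at -2.1, between -2.8 and -1.4.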

Compound 4, distribution coefficient: -1.96
Beside the measured number, compound 4's estimate is 0.14 log units below it; the range from low to high includes it.
By their numbers in this assay, from the lowest: compound 1; then compounds 2 and 4 (each within the scatter of the next).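

With 1-methyl-1-nitroethyl on a saturated chain carbon bound to an oxygen on a saturated carbon, this assay shows a number 0.85 log units higher from compound 1 to compound 4 (beyond the scatter) and so places this group clearly above the methoxymethyl chain. The same read-out gives a number 0.26 log units higher from compound 2 to compound 4 (within the scatter) and so does not separate it from the 2-methoxypropyl chain. Nothing measured here accounts for these readings. On these data alone, the step from nitromethyl in compound 3 to compound 4 cannot be read, so the share of the added carbons stays open. As far as these compounds go, how an amine or a carboxylic acid at this place would read also remains open.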